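Chain length at the amide tail: from compound 2 to compound 3

The source may hold more compounds than are shown below. What is called first, only, known or untested is meant among the compounds shown, and "the series" means these compounds.

Measured compounds:
compound 1, `CN(C)C(=O)c1cc2cnc(Nc3ccc(C(=O)NCCCCN=C=S)cc3)nc2n1C1CCCC1`: 74.2%
compound 2, `CN(C)C(=O)c1cc2cnc(Nc3ccc(C(=O)NCCCCCN=C=S)cc3)nc2n1C1CCCC1`: 76.5%

In a functional assay on NCI-H1299 cells (Homo sapiens) for inhibition, read by CCK-8 assay, with a stated time of 72 h, tested at 10 uM (on this read-out higher numbers stand for a stronger effect at the one concentration tested and lower numbers for a weaker effect), compound 2 gives 76.5%, and compound 1 gives 74.2%. Among the compounds with values here, the two numbers lie within the scatter of each other, so the series so far shows no difference between them; the step of a number 2.3 percentage points higher from compound 1 to compound 2 (within the scatter) is the only one known, and it is flat.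

Compound 3, `CN(C)C(=O)c1cc2cnc(Nc3ccc(C(=O)NCCCCCCN=C=S)cc3)nc2n1C1CCCC1`, has not yet been measured in this assay. It differs from compound 2 by a group of 4 heavy atoms (2 carbon, 1 nitrogen, 1 sulfur; no ring) in place of a group of 3 heavy atoms (1 carbon, 1 nitrogen, 1 sulfur; no ring), on a saturated chain carbon, five bonds along the chain from an amide-type nitrogen. Within the data shown here, this is the same kind of lengthening of the saturated chain as the single known step, moved one bond further along the chain. That step, a number 2.3 percentage points higher from compound 1 to compound 2 (within the scatter), stayed within the scatter, and nothing else in the data bears on the change.

On this basis the expected step of a number 0.5 percentage points higher from compound 2 to compound 3 (within the scatter) is none beyond the scatter. Compound 3 is therefore estimated at 77% in this assay, with a range from 65% to 87%; a result anywhere in that range would be consistent with compounds 1 and 2.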

Compound 3, a percentage reported as inhibition, at one concentration (the size of the read-out at that concentration, not a potency): 85%
Beside the measured number, compound 3's estimate is 8 percentage points below it; measured number inside the range.
By their numbers in this assay, from the lowest: compounds 1, 2 and 3 (each within the scatter of the next, the first and the last beyond it).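

Lengthening the saturated chain by one more carbon, five bonds along the chain from the amide-type nitrogen, gives in this assay a number 8.5 percentage points higher from compound 2 to compound 3 (within the scatter) and so does not by itself separate these two compounds. Across the two-carbon difference, the same chain gives a number 10.8 percentage points higher from compound 1 to compound 3 (beyond the scatter), the first step in the series to lie beyond the scatter, which shows that the length of this chain can affect the read-out once the change spans more than a single carbon, though only modestly and only among these three compounds. No available evidence bears on what underlies this difference.

A longer chain would show whether the read-out keeps climbing beyond compound 3 or levels off, and a shorter chain would show whether the flat stretch seen so far extends downward. Compounds with an amine or a carboxylic acid in place of the isothiocyanate at the end of the chain would show whether the chain length matters apart from that group, and a read-out at several concentrations would show whether the stronger effect at the one concentration tested holds at other concentrations.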